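A few compounds are considered here, and "the series" means these few. Any claim that something is new, unique, unknown or untested is made for them only; others in the source may bear on it.

The compounds share one core, a urea whose aryl side carries a fluorine and a trifluoromethyl group, and differ only in the acid-bearing group on the other urea nitrogen. Compound 1 `CC(C)(NC(=O)Nc1ccc(F)c(C(F)(F)F)c1)C(=O)O` carries a 1-carboxy-1-methylethyl group, compound 2 `O=C(O)CNC(=O)Nc1ccc(F)c(C(F)(F)F)c1` a carboxymethyl group, and compound 3 `O=C(Nc1ccc(F)c(C(F)(F)F)c1)NC1(C(=O)O)CC1` a 1-carboxycyclopropyl group. In a physicochemical assay for solubility, read by nephelometry, measured as kinetic solubility, at pH 2, tested at 10 mg/mL (a higher number here means a more soluble compound, a lower number a less soluble compound), compound 1 gives 25 ug/mL. For compound 2 the assay reports only a limit, > 100 ug/mL. For compound 3 it likewise reports only a limit, > 100 ug/mL. Both an at least 4.0-fold higher number from compound 1 to compound 2 (0.60 log units; beyond the scatter) and an at least 4.0-fold higher number from compound 1 to compound 3 (0.60 log units; beyond the scatter) therefore run upward, whereas a step that the two limits leave unreadable from compound 2 to compound 3 cannot be sized because both ends rest on (the limit of > 100 ug/mL in this assay, at which 2 of the 3 values shown sit).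

Compound 4 `O=C(Nc1ccc(F)c(C(F)(F)F)c1)NC1(C(=O)O)CCC1` enlarges the ring by one carbon: 1-carboxycyclobutyl in place of 1-carboxycyclopropyl on an amide-type nitrogen. Going by the values given here, no measured step covers this exact change. The closest guide is compound 1, whose open-chain 1-carboxy-1-methylethyl group gives 25 ug/mL, while the ring-bearing compound 3 stands higher. Compound 4 is expected to fall between these, at about 60 ug/mL. For compound 4 the expected range runs from 20 ug/mL to 150 ug/mL. The step of an at least 1.6-fold lower number from compound 3 to compound 4 (0.22 log units; that floor lies within the scatter) is thus expected to be a modest drop, its true size uncertain because compound 3 itself sits at the limit of > 100 ug/mL in this assay, at which 2 of the 3 values shown sit.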

Compound 4, solubility: 50 ug/mL
Compound 4: the middle estimate sits 1.2-fold (0.08 log units) above what was measured, and the stated range covers the measured number.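

Going by these compounds alone, compound 4 is the first ring-bearing compound to give a number rather than a limit in this assay, so a group carrying a ring on this amide-type nitrogen can now be placed on the scale. Against the two compounds that rest on a limit, the steps are an at least 2.0-fold lower number from compound 3 to compound 4 (0.30 log units; that floor lies within the scatter) and an at least 2.0-fold lower number from compound 2 to compound 4 (0.30 log units; that floor lies within the scatter), so these data fix only a floor for each step, and neither floor clears the scatter. Against the open-chain group of compound 1, the step is a 2.0-fold higher number from compound 1 to compound 4 (0.30 log units; within the scatter), so 1-carboxycyclobutyl and 1-carboxy-1-methylethyl cannot be told apart on this read-out.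

Going by these compounds, the step from compound 2 to compound 3 cannot be read, and the true size of every other step that starts or ends at those two compounds also stays unknown: the limit of > 100 ug/mL in this assay, at which 2 of the 4 values shown sit. Still open is how the reading would respond to a larger ring, such as 1-carboxycyclopentyl, or to an ester or a primary amide in place of the carboxylic acid on the same ring.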